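Replacing fluoro with dimethylamino on the shared core

The source may report more compounds than this note shows. Statements on the series, on what has been measured and on what is new or still open speak of the compounds shown alone.

Three measured compounds share one core and differ only in the group on the carbonyl carbon of the amide. In a functional assay on A549 cells (Homo sapiens) for antiproliferative activity, read by MTT assay, with a stated time of 72 h (a lower number here means a stronger inhibitor, a higher number a weaker inhibitor), compound 1 `COc1cc(F)c(NC(=O)c2ccnc(Cl)c2)cc1Nc1nccc(-c2cn(C)c3ccccc23)n1` gives 6890 nM, compound 2 `COc1ccc(C(=O)Nc2cc(Nc3nccc(-c4cn(C)c5ccccc45)n3)c(OC)cc2F)nc1` gives 8200 nM, and compound 3 `COc1cc(F)c(NC(=O)c2nccn2C)cc1Nc1nccc(-c2cn(C)c3ccccc23)n1` gives 5140 nM. The steps of a 1.2-fold higher number from compound 1 to compound 2 (0.08 log units; within the scatter), a 1.3-fold lower number from compound 1 to compound 3 (0.13 log units; within the scatter) and a 1.6-fold lower number from compound 2 to compound 3 (0.20 log units; within the scatter) all lie within the scatter, so compound 2 stands among values that cannot be told apart. Compound 4 `COc1ccc(C(=O)Nc2cc(Nc3nccc(-c4cn(C)c5ccccc45)n3)c(OC)cc2N(C)C)nc1` is changed differently: dimethylamino in place of fluoro on an aromatic carbon. Within the data shown here, no measured step touches this position, so nothing here predicts the size or direction of the step; the expectation is therefore no change beyond the scatter, with wide uncertainty. Compound 4 is thus estimated at 9000 nM in this assay, between 2500 nM and 32000 nM, a step of a 1.1-fold higher number from compound 2 to compound 4 (0.04 log units; within the scatter) that is expected rather than known.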

Compound 4, half-maximal inhibitory concentration: 5150 nM
Compound 4: middle estimate off by 1.7-fold (0.24 log units), on the high side, and the stated range covers the measured number.
By their numbers in this assay, from the lowest: compounds 3, 4, 1 and 2 (each within the scatter of the next).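

Among these compounds, this position, on an aromatic carbon ortho to the ((5-methoxypyridin-2-yl)carbonyl)amino group, is varied here for the first time, and in this assay dimethylamino in place of fluoro gives a 1.6-fold lower number from compound 2 to compound 4 (0.20 log units; within the scatter), so three heavy atoms in place of one leave the number within the scatter. No evidence at hand bears on this result.

As far as these compounds go, whether the change behaves the same way with the carbonyl groups of compound 1 or compound 3 stays open. So does the reading of a morpholine or a longer amine chain at this position.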